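The source may hold more compounds than are shown below. What is called first, only, known or untested is meant among the compounds shown, and "the series" means these compounds.

Two compounds of this series carry a measurement in an assay on isolated protein for binding affinity to Equilibrative nucleoside transporter 1 (Homo sapiens); on this read-out lower numbers stand for stronger inhibition and higher numbers for weaker inhibition. Compound 1 `Nc1nc(SCc2ccc(Br)cc2)c2ncn([C@@H]3O[C@H](CO)[C@@H](O)[C@H]3O)c2n1` gives 813 nM in this assay. Compound 2 `OC[C@H]1O[C@@H](n2cnc3c(CSc4c(F)cccc4Cl)ncnc32)[C@H](O)[C@@H]1O` gives 1510 nM in this assay. Compound 2 stands at the highest of the two numbers; its nearest neighbour is compound 1, and the gap between the two values lies within the scatter, so no order between them is claimed. Among the measured compounds shown here, the two structures differ in more than one place, so no single step is computed between them.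

Compound 3 `OC[C@H]1O[C@@H](n2cnc3c(CSc4ccc(F)cc4)ncnc32)[C@H](O)[C@@H]1O` has not yet been measured in this assay. Its structure is computed from compound 2 as 4-fluorophenyl in place of 2-chloro-6-fluorophenyl on a sulfur. For the measured compounds named here, no step between measured compounds bears on this change, and the number for compound 1 rests on a different arrangement of the same part, so the direction stays open. The step of a 1.3-fold lower number from compound 2 to compound 3 (0.10 log units; within the scatter) is expected to stay within the scatter. The estimate for compound 3 in this assay is 1200 nM, with a range from 400 nM to 4000 nM.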

Compound 3, half-maximal inhibitory concentration: 158 nM
Compound 3: middle estimate off by 7.6-fold (0.88 log units), on the high side; the whole stated range lies above it.
By their numbers in this assay, from the lowest: compound 3; then compounds 1 and 2 (each within the scatter of the next).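

Among the compounds shown here, on the sulfur whose other neighbour is a saturated chain carbon, 4-fluorophenyl in place of 2-chloro-6-fluorophenyl gives a 9.6-fold lower number from compound 2 to compound 3 (0.98 log units; beyond the scatter) in this assay, the first single-place change and one that lies beyond the scatter. The aryl group on this sulfur therefore matters to the read-out, although this rests on one pair: the exchange removes the chlorine and changes the ring from 2-chloro-6-fluorophenyl to 4-fluorophenyl, while the counts of hydrogen-bond donors and acceptors and the net charge stay the same. No measurement available here bears on the origin of this step.

This single pair cannot separate the loss of the chlorine from the different fluorine arrangement, and a 2-fluorophenyl or 2-chlorophenyl group on the same sulfur would be needed to tell those contributions apart. Also open, from the compounds shown here alone, is how far the trend extends to other groups at this place, such as unsubstituted phenyl, 4-methoxyphenyl or a benzyl group, and whether it holds on the core of compound 1.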